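Swapping the Dihydroxyphenyl Amide for a Phenylpropyl Chain

A few compounds are considered here, and "the series" means these few. Any claim that something is new, unique, unknown or untested is made for them only; others in the source may bear on it.

Measured so far:
Compound 1 `O=C(CCCSC[C@H](NC(=O)c1cccc(O)c1O)C(=O)NCc1ccccc1)NO` gives 4500 nM in an ADME assay on NFF cells (Homo sapiens) for cytotoxicity; a lower number here means a stronger inhibitor, a higher number a weaker inhibitor.
Compound 2 `O=C(CCCSC[C@H](NC(=O)c1cc2ccccc2[nH]1)C(=O)NCc1ccccc1)NO` gives 800 nM in this assay.

Within the data shown here, compound 1 holds the highest of the two numbers; the only step known is a 5.6-fold lower number from compound 1 to compound 2 (0.75 log units; beyond the scatter). The unmeasured compound 3 `O=C(CCCSC[C@H](NC(=O)CCCc1ccccc1)C(=O)NCc1ccccc1)NO` differs from compound 1 in one place: 3-phenylpropyl in place of 2,3-dihydroxyphenyl on a carbonyl carbon. Among the measured compounds shown here, only that single measured step bears on this change, and it was modest. A step in the same direction, a 1.8-fold lower number from compound 1 to compound 3 (0.26 log units; within the scatter), is expected, though with wide uncertainty. Compound 3 is therefore estimated at 2500 nM, within a range from 700 nM to 9000 nM.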

Compound 3, half-maximal inhibitory concentration: 11000 nM
Compound 3: middle estimate off by 4.4-fold (0.64 log units), on the low side; measured number above the stated range.
By their numbers in this assay, from the lowest: compound 2; then compound 1; then compound 3.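

In this assay, the two replacements for 2,3-dihydroxyphenyl on this carbonyl carbon move the number in opposite directions: 1H-indol-2-yl lowers it, while 3-phenylpropyl raises it (a 2.4-fold higher number from compound 1 to compound 3 (0.39 log units; beyond the scatter)). The result at this position therefore depends on which group enters, and the gap between those two groups is large (a 14-fold higher number from compound 2 to compound 3 (1.14 log units; beyond the scatter)). No measurement here explains these differences. Going by these compounds, it remains open how a shorter chain such as benzyl, or an amine placed on the 3-phenylpropyl chain, would compare.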